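The source may hold more compounds than are shown below. What is called first, only, known or untested is meant among the compounds shown, and "the series" means these compounds.

Measured so far in a functional assay on GBM2 cells (Homo sapiens) for antiproliferative activity, read by WST assay, with a stated time of 72 h; a higher number here means a weaker inhibitor, a lower number a stronger inhibitor:
- compound 1 `O=C(Nc1cccc(Cl)c1)Nc1cc2ncncc2cc1OCc1ccccc1Cl`: 2100 nM
- compound 2 `O=C(Nc1cccc(Cl)c1)Nc1cc2ncncc2cc1OCc1cccc(Cl)c1`: 3500 nM

Compound 2 stands within the scatter of compound 1, so the two numbers set no order. Within the data shown here, the only measured step is a 1.7-fold higher number from compound 1 to compound 2 (0.22 log units; within the scatter). It replaces 2-chlorophenyl with 3-chlorophenyl on a saturated chain carbon bound to an oxygen on an aromatic ring.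

Next is compound 3 `O=C(Nc1ccccc1F)Nc1cc2ncncc2cc1OCc1cccc(Cl)c1`, which carries 2-fluorophenyl in place of 3-chlorophenyl on an amide-type nitrogen. Among the measured compounds shown here, compounds 1 and 2 both have 3-chlorophenyl at that nitrogen, so no measured step tests this place. The step at the other place bears on it only loosely, and it shows a change of aryl substitution staying small: a 1.7-fold higher number from compound 1 to compound 2 (0.22 log units; within the scatter). No direction can be drawn from these data, so nothing beyond the scatter is expected in this assay, though with little confidence. The estimated change is a 1.1-fold higher number from compound 2 to compound 3 (0.06 log units; within the scatter). For compound 3 the expected value is 4000 nM, with an estimated range from 1300 nM to 12000 nM.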

Compound 3, half-maximal inhibitory concentration: 4400 nM
Compound 3: middle estimate off by 1.1-fold (0.04 log units), on the low side; the range from low to high includes it.
By their numbers in this assay, from the lowest: compounds 1, 2 and 3 (each within the scatter of the next, the first and the last beyond it).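

The amide-type nitrogen now has its first measured step: in this assay, 2-fluorophenyl in place of 3-chlorophenyl gives a 1.3-fold higher number from compound 2 to compound 3 (0.10 log units; within the scatter) and so sets no order between the two compounds. The halogen and its printed ring number change together in this step, so a single pair cannot separate the two changes, and a difference hidden within the scatter cannot be excluded. No line of measurement on any property of these compounds bears on this result.

The compounds shown all keep a halogen-bearing phenyl group on the amide-type nitrogen, so it remains open whether a pyridyl ring, a cyclohexyl ring or a longer alkyl chain there would give a step beyond the scatter, and whether an amine or a carboxylic acid on that phenyl ring would do so. The same question stands for the chlorophenyl group on the saturated chain carbon bound to the oxygen, where a methoxy group, an unsubstituted phenyl group or a longer chain would show how much of that part the number in this assay depends on.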